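Aryl substitution on the aryl-ether methyl of compound 1

The source may hold more compounds than are shown below. What is called first, only, known or untested is meant among the compounds shown, and "the series" means these compounds.

Compound 1 `COc1ccc(OCCOCCNC2CCCC2)cc1` gives 99100 nM in a functional assay on SK-OV-3 cells (Homo sapiens) for inhibition, read by CCK-8 assay, with a stated time of 70 h (a higher number here means a weaker inhibitor, a lower number a stronger inhibitor), the highest of the three numbers recorded. Compound 2 `OCCOCCOCCOc1ccc(OCc2ccccc2)cc1` gives 59400 nM, a gap from compound 1 that stays within the scatter. Compound 3 `O=[N+]([O-])c1ccccc1COc1ccc(OCCOCCNC2CCCCC2)cc1` gives 2880 nM, a gap from compound 1 that lies beyond the scatter, the lower number belonging to compound 3. Compound 4 `O=C(O)c1ccc(COc2ccc(OCCOCCNC3CCCC3)cc2)cc1` is unmeasured; it differs from compound 1 by 4-carboxyphenyl in place of hydrogen on a saturated chain carbon bound to an oxygen on an aromatic ring. Within the data shown here, compound 3 also carries an aromatic group at this position and shows the lowest number of the set, so a move toward lower numbers is expected, though the 4-carboxyphenyl group has no measured counterpart here. The expected step of a 6.6-fold lower number from compound 1 to compound 4 (0.82 log units; beyond the scatter) is therefore sizable but uncertain. Compound 4 is estimated at 15000 nM, within 3000 nM to 70000 nM.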

Compound 4, half-maximal inhibitory concentration: > 100000 nM
Compound 4: only a limit was reported; the forecaster's own chance of this, stated with the estimate: 10%; at least 6.6-fold (0.82 log units) between middle value and limit.
By their numbers in this assay, from the lowest: compound 3; then compounds 2 and 1 (each within the scatter of the next). At a limit, above all of these: compound 4.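

In this assay compound 4 gives > 100000 nM, a limit of the assay and not a number. Thus there is a number no lower from compound 1 to compound 4 (the limit leaves the size open) with 4-carboxyphenyl in place of hydrogen on a saturated chain carbon bound to an oxygen on an aromatic ring, so an aromatic group here does not by itself give a lower number. The size of this step cannot be read, and the limit marks the edge of what the series can show: the limit of > 100000 nM in this assay, at which 1 of the 4 values shown sits. Open, going by these compounds, is whether plain phenyl at this place, or a methyl ester or primary amide in place of the carboxylic acid, would give a lower number.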